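From 4-fluorophenyl to phenyl on the triple bond

This account rests on a few compounds, and the source may have more. Where it says the series, first, only, none or still open, it means among the compounds named here.

In a functional assay on CAPAN-1 cells (Homo sapiens) for antiproliferative activity, with a stated time of 72 h (on this read-out lower numbers stand for stronger inhibition and higher numbers for weaker inhibition), compound 1 `Nc1ncnn2c([C@@H]3O[C@H](CO)[C@@H](O)[C@H]3O)cc(C#CC3CC3)c12` gives 20 nM, while compound 2 `Nc1ncnn2c([C@@H]3O[C@H](CO)[C@@H](O)[C@H]3O)cc(C#Cc3ccc(F)cc3)c12` gives 55400 nM, the higher of the two numbers. Compound 3 `Nc1ncnn2c([C@@H]3O[C@H](CO)[C@@H](O)[C@H]3O)cc(C#Cc3ccccc3)c12` differs from compound 2 by hydrogen in place of fluoro on an aromatic carbon, with hydrogen in place of fluoro on an aromatic carbon. Among the measured compounds shown here, the only measured step, a 2800-fold higher number from compound 1 to compound 2 (3.44 log units; beyond the scatter), exchanges the whole cyclopropyl for 4-fluorophenyl, so it bears only loosely on this smaller change. Compound 3 keeps the six-membered aromatic ring, so a value near compound 2 is expected. The estimated step is a 1.8-fold lower number from compound 2 to compound 3 (0.27 log units; within the scatter), small and toward a lower number. For compound 3 the expected value is 30000 nM, within 6000 nM to 100000 nM.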

Compound 3, half-maximal inhibitory concentration: 37700 nM
Compound 3: middle estimate off by 1.3-fold (0.10 log units), on the low side; the measured number falls inside the stated range.
By their numbers in this assay, from the lowest: compound 1; then compounds 3 and 2 (each within the scatter of the next).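

Hydrogen in place of fluoro gives a 1.5-fold lower number from compound 2 to compound 3 (0.17 log units; within the scatter) in this assay, so the para fluoro is not what sets this pair apart from compound 1. With no fluoro at all, phenyl in place of cyclopropyl on a triple-bonded carbon still gives a 1900-fold higher number from compound 1 to compound 3 (3.28 log units; beyond the scatter), and the large gap stays. Nothing measured here accounts for that gap. The compounds shown leave open how the number moves between cyclopropyl and phenyl, as with a cyclohexyl or a short alkyl chain on the triple-bonded carbon. They also leave open whether an amine on the phenyl ring would change it.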